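A few compounds are considered here, and "the series" means these few. Any claim that something is new, unique, unknown or untested is made for them only; others in the source may bear on it.

Measured so far:
compound 1 `C#CCOc1ccc2ncnc(NCc3ccccc3)c2c1`, in a functional assay on HepG2 cells (Homo sapiens) for cytotoxicity, read by MTT assay; on this read-out higher numbers stand for weaker inhibition and lower numbers for stronger inhibition: > 200000 nM
compound 2 `O=[N+]([O-])c1cccc(-n2cc(COc3ccc4ncnc(NCc5ccccc5)c4c3)nn2)c1`, in this assay : compound 2 gives 94100 nM.

The result of compound 1 is a limit of this assay rather than a number, the value given as > 200000 nM. For the measured compounds named here, compound 2 is the only one of the two with a numerical result in this assay, at 94100 nM; no measured step between two compounds exists here, and the one line of supporting evidence is simply (the limit of > 200000 nM in this assay, at which 1 of the 2 values shown sits).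

Compound 3 `CN1CCN(c2ncnc3ccc(OCc4cn(-c5cccc([N+](=O)[O-])c5)nn4)cc23)CC1` has not yet been measured. It differs from compound 2 in one place: 4-methylpiperazin-1-yl in place of benzylamino on an aromatic carbon. Going by the values given here, since no measured step exists between any two compounds, there is nothing in the numbers on which to rest a direction for this change. The expected step from compound 2 to compound 3 in this assay is therefore estimated as a 1.0-fold lower number from compound 2 to compound 3 (0.02 log units; within the scatter), that is, none beyond the usual scatter. On that basis compound 3 is expected to give about 90000 nM in this assay, within an estimated range from 30000 nM to 250000 nM.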

Compound 3, half-maximal inhibitory concentration: > 200000 nM
Compound 3 ended at the assay's limit; the forecaster's own chance of this, stated with the estimate: 35%; at least 2.2-fold (0.34 log units) between middle value and limit.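

In this assay, putting 4-methylpiperazin-1-yl in place of benzylamino on this aromatic carbon of the shared core gives an at least 2.1-fold higher number from compound 2 to compound 3 (0.32 log units; beyond the scatter), so inhibition becomes weaker by more than the usual scatter. This shows that the position is not indifferent to the group it carries, and that the measurable effect of compound 2 does not survive this change. The result for compound 3, > 200000 nM, is a limit of the assay and not a number, so the step gives only a minimum size and its true size remains unknown: the limit of > 200000 nM in this assay, at which 2 of the 3 values shown sit.

The change alters several features at once: a six-membered aromatic ring of carbon only and a hydrogen-bond donor leave, while a non-aromatic ring with hetero atoms enters, and the compounds shown cannot separate these features. A simple aniline at the same place would keep the donor and an aromatic ring without the methylene link, while a morpholin-4-yl group would stay closer to the entering ring, so each could help show which feature matters.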